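Hydroxyphenyl-substituted pyridines: moving one hydroxyl

This account rests on a few compounds, and the source may have more. Where it says the series, first, only, none or still open, it means among the compounds named here.

Measured compounds:
compound 1, `Oc1ccc(-c2cc(-c3ccccc3F)cc(-c3ccc(O)cc3)n2)cc1`, 15100 nM
compound 2, `Oc1ccc(-c2cc(-c3ccccc3C(F)(F)F)cc(-c3ccc(O)cc3)n2)cc1`, > 50000 nM
compound 3, `Oc1ccc(-c2cc(-c3ccccc3OC(F)(F)F)cc(-c3cccc(O)c3)n2)cc1`, 7300 nM

In a functional assay on T47D cells (Homo sapiens) for inhibition (a lower number here means a stronger inhibitor, a higher number a weaker inhibitor), compound 1 gives 15100 nM. For compound 2 the value in this assay is a limit, > 50000 nM, so its number is not known; this is the limit described in the limit of > 50000 nM in this assay, at which 1 of the 3 values shown sits. Within the data shown here, the only step measured in one place, an at least 3.3-fold higher number from compound 1 to compound 2 (0.51 log units; beyond the scatter), concerns the group on the third aryl ring and not the hydroxyl position. Compound 3 gives 7300 nM and stands as the lowest of the two numbers shown, with compound 1 as the nearest value.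

Compound 4, `Oc1ccc(-c2cc(-c3ccccc3OC(F)(F)F)cc(-c3ccc(O)cc3)n2)cc1`, is not yet measured. It differs from compound 3 only in the hydroxyl position: 4-hydroxyphenyl in place of 3-hydroxyphenyl on an aromatic carbon. No measured pair varies this position, so no step shown bears on it directly; compounds 1 and 2 both carry the 4-hydroxyphenyl arrangement of compound 4, but differ from it elsewhere. Among the measured compounds shown here, with no guiding step, a change no larger than the scatter is expected for a 1.4-fold higher number from compound 3 to compound 4 (0.14 log units; within the scatter). The expected value for compound 4 in this assay is therefore 10000 nM, within a range of 3000 nM to 40000 nM.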

Compound 4, half-maximal inhibitory concentration: 9840 nM
Estimate against measurement, compound 4: 1.0-fold (0.01 log units) above; measured number inside the range.
By their numbers in this assay, from the lowest: compounds 3, 4 and 1 (each within the scatter of the next, the first and the last beyond it). At a limit, above all of these: compound 2.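

In this assay, the hydroxyl position has its first direct comparison, a 1.3-fold higher number from compound 3 to compound 4 (0.13 log units; within the scatter), so with trifluoromethoxy on the other aryl ring, 3-hydroxyphenyl and 4-hydroxyphenyl next to the ring nitrogen are not told apart. With 4-hydroxyphenyl held constant, the aryl substituent can be read further: a 1.5-fold lower number from compound 1 to compound 4 (0.19 log units; within the scatter) leaves trifluoromethoxy and fluoro unseparated, whereas an at least 5.0-fold lower number from compound 2 to compound 4 (0.70 log units; beyond the scatter) separates trifluoromethoxy from trifluoromethyl. The value of compound 2 behind that last step is a limit, not a number: the limit of > 50000 nM in this assay, at which 1 of the 4 values shown sits.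

Among these compounds, the only pair varying the hydroxyl position carries trifluoromethoxy, so the same change with fluoro or trifluoromethyl on that ring remains open. Also open, on these data alone, is how an amine or a carboxylic acid in place of either hydroxyl would read.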